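The compounds below may be only part of what the source reports. "The series", "measured", "known", "first", "only" and "open" are said of these compounds alone.

Of the compounds shown here, two have numbers so far in a functional assay on HGC-27 cells (Homo sapiens) for antiproliferative activity, read by MTT assay, with stated times of 72 h and 4 h (on this read-out higher numbers stand for weaker inhibition and lower numbers for stronger inhibition), and they stand well apart. Compound 1 (`COc1ncc(-c2cc3c(N4CCCC4)ncnc3s2)cc1NS(=O)(=O)c1ccc(F)cc1F`) gives 2300 nM while compound 2 (`COc1ncc(-c2nc3c(N4CC(C)OC(C)C4)ncnc3s2)cc1NS(=O)(=O)c1ccc(F)cc1F`) gives 270 nM as the lower of the two numbers, a gap beyond the scatter. These two structures differ in more than one place, so the gap cannot be tied to any single change. Compound 3 (`COc1ncc(-c2nc3c(N4CCCCC4)ncnc3s2)cc1NS(=O)(=O)c1ccc(F)cc1F`) has not yet been measured in this assay but departs from compound 2 in one place only, with piperidin-1-yl in place of 2,6-dimethylmorpholin-4-yl on an aromatic carbon. For the measured compounds named here, no measured pair isolates this exchange, so any expectation rests on thin ground. Going by the values given here, the only other reference is compound 1 at 2300 nM and it shows that a compound sharing much of this structure can lie well above compound 2. A small rise in the number is therefore expected, within or just beyond the scatter, and no real change would also fit. An estimated step of a 1.7-fold higher number from compound 2 to compound 3 (0.22 log units; within the scatter) is expected. For compound 3 the expected value is 450 nM with an estimated range from 130 nM to 1500 nM on this read-out.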

Compound 3, half-maximal inhibitory concentration: 960 nM
The estimate for compound 3 lay 2.1-fold (0.33 log units) below the measured number; measured number inside the range.
By their numbers in this assay, from the lowest: compound 2; then compound 3; then compound 1.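

In this assay, piperidin-1-yl in place of 2,6-dimethylmorpholin-4-yl on this aromatic carbon gives a 3.6-fold higher number from compound 2 to compound 3 (0.55 log units; beyond the scatter), a modest step, and this is the only pair shown that isolates a single change. It shows that the group at this position, opposite the ring nitrogen, bears on the number, and that of these two six-membered rings the 2,6-dimethylmorpholin-4-yl goes with the lower number, although the exchange alters the hetero atoms and the heavy-atom count together, so the step cannot be assigned to either alone. No measurement offered here bears on why the number rises.

Going by these compounds, whether the step follows the ring oxygen or the two methyl groups remains open, and a morpholin-4-yl group without the methyl groups would separate the two, while a piperazin-1-yl ring would test a second ring nitrogen in the same place. Compound 1 differs from compound 2 and compound 3 in more than one place, so steps to it cannot be read, and the pair shown cannot say whether the same exchange would carry the same size of step on the core of compound 1.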